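Chloro to methyl on the shared core: solubility notes

This account rests on a few compounds, and the source may have more. Where it says the series, first, only, none or still open, it means among the compounds named here.

Measured compounds in this series:
compound 1 `Cc1c(COc2cccc(OCC3CCOCC3)c2)[nH]c2ccc(Cl)cc2c1=O`: < 1000 nM
compound 2 `O=c1c(Cl)c(COc2cccc(OCC3CCOCC3)c2)[nH]c2ccccc12`: 2000 nM
compound 3 `O=c1cc(COc2cccc(OCC3CCOCC3)c2)[nH]c2ccccc12`: 4000 nM

In a physicochemical assay for solubility, at pH 6.8 (a lower number here means a less soluble compound, a higher number a more soluble compound), compound 1 gives < 1000 nM, which is a limit of the assay and not a number. Compound 2 gives 2000 nM and compound 3 gives 4000 nM. Within the data shown here, the single measured step between them, a 2.0-fold higher number from compound 2 to compound 3 (0.30 log units; within the scatter), is within the scatter, so removing the chloro on an aromatic carbon left this assay unchanged as far as can be told.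

Compound 4 `Cc1ccc2[nH]c(COc3cccc(OCC4CCOCC4)c3)c(C)c(=O)c2c1` differs from compound 1 by methyl in place of chloro on an aromatic carbon. Compound 1 itself stands only as a limit in this assay, (the limit of < 1000 nM in this assay, at which 1 of the 3 values shown sits), so its position on the scale is not a number. Among the measured compounds shown here, the one step that bears on the change, a chloro leaving an aromatic carbon, showed no movement beyond the scatter, and the methyl that enters counts the same single heavy atom. No step beyond the scatter is expected for a step that the limit leaves unreadable from compound 1 to compound 4. Compound 4 is therefore estimated at 800 nM in this assay. The expected range for compound 4 runs from 250 nM to 2500 nM, with a real chance that this assay again reports only a limit.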

Compound 4, solubility: < 1000 nM
Compound 4 was reported as a limit (the forecaster's own chance of this, stated with the estimate: 55%); the middle value lies beyond the limit too.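

Compound 1 and compound 4 both stand only as limits of the assay in this assay, so no step can be read for methyl in place of chloro: the limit of < 1000 nM in this assay, at which 2 of the 4 values shown sit.

The compounds shown leave open whether this exchange on the shared core changes the read-out at all.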